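Vinyl in place of prop-1-en-1-yl: compound 2 to compound 3

A few compounds are considered here, and "the series" means these few. Any claim that something is new, unique, unknown or untested is made for them only; others in the source may bear on it.

compound 1 `CCOC(=O)c1cc(-c2ccc(Oc3ccccc3)cc2)nn1Cc1cccc(NC(=O)CCl)c1`: 400 nM
compound 2 `C/C=C/C(=O)Nc1cccc(Cn2nc(-c3ccc(Oc4ccccc4)cc3)cc2C(=O)OCC)c1`: 7800 nM

In a functional assay on Rec1 cells (Homo sapiens) for inhibition, read by luminescence and CellTiter-Glo, with a stated time of 72 h (on this read-out lower numbers stand for stronger inhibition and higher numbers for weaker inhibition), compound 2 gives 7800 nM and stands highest of the two measured compounds. Compound 3 `C=CC(=O)Nc1cccc(Cn2nc(-c3ccc(Oc4ccccc4)cc3)cc2C(=O)OCC)c1` is the next case. Its change is vinyl in place of prop-1-en-1-yl on a carbonyl carbon with vinyl in place of prop-1-en-1-yl on a carbonyl carbon whose other neighbour is an amide-type nitrogen.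

Among the measured compounds shown here, one measured step bears on this place. It is a 20-fold higher number from compound 1 to compound 2 (1.29 log units; beyond the scatter) and came with prop-1-en-1-yl in place of chloromethyl on the same carbonyl carbon. For the measured compounds named here, that single step shows that this assay can respond strongly to a change here, but no vinyl compound has been measured yet. A lower number than for compound 2 is therefore expected, though a smaller move than the measured step. The expected step is a 6.5-fold lower number from compound 2 to compound 3 (0.81 log units; beyond the scatter) in this estimate. For compound 3 the estimated value is 1200 nM with an expected range from 300 nM to 5000 nM in this assay.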

Compound 3, half-maximal inhibitory concentration: 3300 nM
Compound 3: the middle estimate sits 2.8-fold (0.44 log units) below what was measured; the measured number falls inside the stated range.
By their numbers in this assay, from the lowest: compound 1; then compound 3; then compound 2.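

In this assay, a 2.4-fold lower number from compound 2 to compound 3 (0.37 log units; beyond the scatter) shows that this place on the carbonyl carbon also responds to a small change, from prop-1-en-1-yl to vinyl, and not only to the replacement of chloromethyl. Even so, an 8.3-fold higher number from compound 1 to compound 3 (0.92 log units; beyond the scatter) leaves chloromethyl with the lowest number of the three groups shown here, with vinyl in the middle and prop-1-en-1-yl highest. Nothing available explains this order.

Going by these compounds, it remains open where a group such as bromomethyl or a longer chain such as butyl, or a dimethylamino-bearing chain, would fall in this order on the same carbonyl carbon. On these data alone, all three compounds share one core, so whether the order carries over to a different core also stays open.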